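A few compounds are considered here, and "the series" means these few. Any claim that something is new, unique, unknown or untested is made for them only; others in the source may bear on it.

The measured compounds and their values:

Compound 1 `CC(C)OC(=O)N1CCC(O[C@H]2CC[C@H](Oc3ccc(S(C)(=O)=O)nc3)CC2)CC1` gives 101%.
Compound 2 `Cc1nc(S(C)(=O)=O)ccc1O[C@H]1CC[C@H](OC2CCN(C(=O)OC(C)C)CC2)CC1` gives 108%.
Compound 3 `CC(C)(C)OC(=O)N1CCC(O[C@H]2CC[C@H](Oc3cnc(C#N)cn3)CC2)CC1` gives 110%.

In a functional assay on isolated protein for agonist activity at Glucose-dependent insulinotropic receptor (Homo sapiens), read by HTRF and cAMP accumulation (a lower number here means a smaller maximal response, a higher number a larger maximal response), compound 1 stands lowest of the three numbers, but its neighbours are close: compound 2 is a number 7 percentage points higher from compound 1 to compound 2 (within the scatter), which is within the scatter, and the value of compound 3 is also within the scatter of compound 1. All three compounds therefore behave as full agonists, each reaching roughly the response of the reference.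

Compound 4 `CC(C)OC(=O)N1CCC(O[C@H]2CC[C@H](Oc3cnc(S(C)(=O)=O)cn3)CC2)CC1` has not yet been measured. It differs from compound 1 in one place: 5-(methylsulfonyl)pyrazin-2-yl in place of 6-(methylsulfonyl)pyridin-3-yl on an oxygen on a saturated carbon. The aromatic ring carrying the methylsulfonyl group is thus exchanged for one with an extra ring nitrogen.

Among the measured compounds shown here, no measured step follows exactly this exchange. The one step shown, from compound 1 to compound 2, concerns a methyl group on the aromatic ring and stays within the scatter. Compound 3, which carries a pyrazine ring, also gives a value close to compound 1, though with a different substituent, so no listed step connects them. Nothing in these numbers points to a change beyond the scatter, and the expected step in this assay is a number 4 percentage points higher from compound 1 to compound 4 (within the scatter).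

Compound 4 is therefore expected to give 105%, in a range from 90% to 120%.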

Compound 4, largest response reached (Emax), in percent of the reference or control that the assay uses: 110%
Beside the measured number, compound 4's estimate is 5 percentage points below it; measured number inside the range.
By their numbers in this assay, from the lowest: compounds 1, 2, 3 and 4 (each within the scatter of the next).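

In this assay, putting 5-(methylsulfonyl)pyrazin-2-yl in place of 6-(methylsulfonyl)pyridin-3-yl on an oxygen on a saturated carbon gives a number 9 percentage points higher from compound 1 to compound 4 (within the scatter). This is the first comparison shown that changes the atoms of the aromatic ring itself while keeping the methylsulfonyl group and the rest of the molecule, and the largest response stays unresolved from that of the parent: this position tolerates a six-membered aromatic ring with 2 hetero atoms in place of one with 1 without any measurable loss. No measurement shown explains this result or tells what the additional ring nitrogen does.

The compounds shown leave open whether the response would hold if a carboxylic acid or an amine replaced the methylsulfonyl group on this ring, or if a plain phenyl ring with no ring nitrogen carried it. Since this read-out gives only the largest response reached, it also leaves open whether the ring exchange alters how much compound is needed to reach that response.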